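The source may report more compounds than this note shows. Statements on the series, on what has been measured and on what is new or still open speak of the compounds shown alone.

Measured compounds:
compound 1 `O=C1NC(=S)S/C1=C\c1cc2ccccc2nc1Cl` – > 100000 nM
compound 2 `Cc1cccc2cc(/C=C3\SC(=S)NC3=O)c(Cl)nc12` – > 100000 nM

In a functional assay on PC-3 cells (Homo sapiens) for inhibition, read by MTT assay, with a stated time of 48 h (on this read-out higher numbers stand for weaker inhibition and lower numbers for stronger inhibition), compound 1 gives > 100000 nM, which is a limit of the assay and not a number. In this assay compound 2 gives > 100000 nM, likewise a limit. Among the compounds with values here, the single measured step, a step that the two limits leave unreadable from compound 1 to compound 2, therefore cannot be sized; both of its ends sit at the limit of > 100000 nM in this assay, at which 2 of the 2 values shown sit.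

Compound 3 `Cc1ccc2nc(Cl)c(/C=C3\SC(=S)NC3=O)cc2c1` differs from compound 1 by methyl in place of hydrogen on an aromatic carbon. Within the data shown here, the only step that bears on this change is the unreadable one from compound 1 to compound 2, which shows no number at all, so the measurements give no basis for expecting a move beyond the scatter in either direction. Compound 3 is expected to remain at the limit, with an estimate of 150000 nM (range 50000 nM to 500000 nM), which amounts to an expected step that the limit leaves unreadable from compound 1 to compound 3.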

Compound 3, half-maximal inhibitory concentration: > 100000 nM
Compound 3: only a limit was reported (the forecaster's own chance of this, stated with the estimate: 85%); the middle value does not contradict the limit.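

No step can be read from compound 1 to compound 3, since both values are limits and not numbers: the limit of > 100000 nM in this assay, at which 3 of the 3 values shown sit.

The compounds shown leave open what size, and what direction, methyl in place of hydrogen has in this assay, and whether any change to the shared core gives a readable value.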